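A few compounds are considered here, and "the series" means these few. Any claim that something is new, unique, unknown or untested is made for them only; others in the source may bear on it.

Of the compounds shown here, three have so far been measured in an assay on CHO cells for activation of soluble guanylate cyclase alpha1/beta1 complex (Homo sapiens), read by cGMP accumulation; on this read-out higher numbers stand for an effect only at larger amounts of compound and lower numbers for an effect already at smaller amounts. Compound 1 `COC(=O)N(C)c1c(N)nc(-n2nc(Cc3ccccc3F)c3ccccc32)nc1N` gives 310 nM in this assay. Compound 2 `CC1(C)C(=O)Nc2nc(-n3nc(Cc4ccccc4F)c4ccccc43)nc(N)c21` gives 3000 nM, and compound 3 `COC(=O)N(C)c1c(N)nc(-c2nc(Cc3ccccc3F)n3ccccc23)nc1N` gives 20400 nM. Among these three numbers compound 2 stands second highest: compound 3 sits nearest to it with a higher number, and compound 1 lies furthest from it with a lower one; both gaps are beyond the usual scatter of repeated measurements.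

Compound 4 `CC1(C)C(=O)Nc2nc(-n3nc(Cc4c(F)ccc(F)c4F)c4ccccc43)nc(N)c21` has not yet been measured. It differs from compound 2 in a single place: 2,3,6-trifluorophenyl in place of 2-fluorophenyl on a saturated chain carbon bound to an aromatic carbon. Everything else in the structure stays as it is in compound 2.

Within the data shown here, no measured pair shows the effect of this particular change, so the expectation rests on compound 2 alone, with a modest shift allowed for. The expected step is small and points toward a slightly lower number: a 1.7-fold lower number from compound 2 to compound 4 (0.22 log units; within the scatter). Compound 4 is therefore estimated at 1800 nM in this assay, with a likely range from 500 nM to 6000 nM.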

Compound 4, half-maximal effective concentration: 2000 nM
Beside the measured number, compound 4's estimate is 1.1-fold (0.05 log units) below it, within the range that was stated.
By their numbers in this assay, from the lowest: compound 1; then compounds 4 and 2 (each within the scatter of the next); then compound 3.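

In this assay, putting 2,3,6-trifluorophenyl in place of 2-fluorophenyl on a saturated chain carbon bound to an aromatic carbon gives a 1.5-fold lower number from compound 2 to compound 4 (0.18 log units; within the scatter), so the two compounds cannot be told apart. This is the first change at this position among the compounds shown, and it indicates that the added fluorine atoms leave the read-out within the usual scatter on this core. Nothing available explains why the read-out holds steady under this change.

From the compounds shown here alone, how the read-out responds to other groups here stays open, for example an unsubstituted benzyl, a methoxy on the ring, an amine on the ring or a longer chain. Going by these compounds, it is also open whether the same change would read alike on the core of compound 1, which gives 310 nM.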